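The source may hold more compounds than are shown below. What is called first, only, known or untested is meant among the compounds shown, and "the series" means these compounds.

Measured so far in an ADME assay on L02 cells (Homo sapiens) for antiproliferative activity, read by MTT assay, with a stated time of 48 h; a higher number here means a weaker inhibitor, a lower number a stronger inhibitor:
- compound 1 `CCOc1ccc(NC(=O)c2ccc(C(CC)(CC)c3ccc(OCCC(O)(CC)CC)c(C)c3)n2CC)cc1`: > 50000 nM (a limit of the assay, not a number)
- compound 2 `CCC(C)C(NC(=O)c1ccc(C(CC)(CC)c2ccc(OCCC(O)(CC)CC)c(C)c2)n1CC)C(=O)O`: 9990 nM

Going by the values given here, compound 2, at 9990 nM, holds the only true number in this assay. The result for compound 1 is a limit: the limit of > 50000 nM in this assay, at which 1 of the 2 values shown sits. The next compound to read is compound 3 `CCn1c(C(=O)N(C)CCO)ccc1C(CC)(CC)c1ccc(OCCC(O)(CC)CC)c(C)c1`. Its change from compound 2 is (2-hydroxyethyl)(methyl)amino in place of (1-carboxy-2-methylbutyl)amino on a carbonyl carbon, and no ring enters.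

Among the compounds with values here, one measured step bears on this, and only indirectly. It is an at least 5.0-fold lower number from compound 1 to compound 2 (0.69 log units; beyond the scatter), and it shows that the group at this amide-type nitrogen can move the read-out beyond the scatter. That step replaced a 4-ethoxyphenyl group, however, so it gives no direct measure of the present exchange between two groups without a ring. A modest shift towards weaker inhibition is expected, with a limit result still possible. The estimated change is a 2.0-fold higher number from compound 2 to compound 3 (0.30 log units; within the scatter). For compound 3 the estimated value is 20000 nM, with an expected range of 7000 nM to 50000 nM.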

Compound 3, half-maximal inhibitory concentration: 2050 nM
Compound 3: middle estimate off by 9.8-fold (0.99 log units), on the high side; measured number outside the range, below it.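

In this assay, the group on the carbonyl carbon now has a measured exchange between two groups without a ring, and it gives a 4.9-fold lower number from compound 2 to compound 3 (0.69 log units; beyond the scatter) with (2-hydroxyethyl)(methyl)amino in place of (1-carboxy-2-methylbutyl)amino. Going by these compounds alone, the earlier step at this position replaced a 4-ethoxyphenyl group, so this is the first evidence that the read-out also moves beyond the scatter when no ring is involved, and the smaller of the two groups here gives the lower number. Compared with compound 1, the same group gives an at least 24-fold lower number from compound 1 to compound 3 (1.38 log units; beyond the scatter) but this is only a bound, as compound 1 has a limit and not a number: the limit of > 50000 nM in this assay, at which 1 of the 3 values shown sits.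

The exchange removes the carboxylic acid and the branched chain, and also adds a methyl group on the amide nitrogen and a hydroxyl group, so the compounds shown do not assign the step to any one of these changes. A plain dimethylamino group, a 2-hydroxyethylamino group without the methyl, or a short chain ending in a carboxylic acid would separate these contributions.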